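The source may report more compounds than this note shows. Statements on the series, on what has been measured and on what is new or still open speak of the compounds shown alone.

Measured in a functional assay on DU-145 cells (Homo sapiens) for cytotoxicity, read by MTT assay, with a stated time of 48 h; on this read-out higher numbers stand for weaker inhibition and lower numbers for stronger inhibition:
- Compound 1 `COc1ccc(/C=C/C(=O)/C=C/c2cc3ccccc3nc2Oc2ccc(Br)cc2)cc1OC`: > 10000 nM, a limit.
- Compound 2 `COc1ccc(/C=C/C(=O)/C=C/c2cc3ccccc3nc2Oc2cccc(Cl)c2)c(OC)c1`: > 10000 nM, a limit.

The data so far amount to the limit of > 10000 nM in this assay, at which 2 of the 2 values shown sit. Within the data shown here, compound 2 therefore stands only at a limit and has no numerical value, and the one other value, for compound 1, is a limit too.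

Compound 3 `COc1ccc(/C=C/C(=O)/C=C/c2cc3ccccc3nc2Oc2cccc(Cl)c2)cc1OC` has the same atoms as compound 2, joined differently: 3,4-dimethoxyphenyl in place of 2,4-dimethoxyphenyl on a double-bonded chain carbon bound to a double-bonded chain carbon. Among the measured compounds shown here, no measured step is available to size this change. In this assay a shift no larger than the usual scatter is expected, with no direction favoured, and a further limit is the likeliest report. The estimated step that the limit leaves unreadable from compound 2 to compound 3 is correspondingly small. For compound 3 the estimate is 12000 nM, with an expected range of 4000 nM to 30000 nM.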

Compound 3, half-maximal inhibitory concentration: > 10000 nM
Compound 3: a limit, no number; the forecaster's own chance of this, stated with the estimate: 75%; the middle value is on the limit's open side.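

No step can be read from compound 1 or compound 2 to compound 3, as all three stand at one limit: the limit of > 10000 nM in this assay, at which 3 of the 3 values shown sit.

The compounds shown leave open whether 3,4-dimethoxyphenyl in place of 2,4-dimethoxyphenyl, or 3-chlorophenyl in place of 4-bromophenyl, moves the read-out at all.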